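Trading trifluoromethyl for ethyl on the aromatic ring

A few compounds are considered here, and "the series" means these few. Any claim that something is new, unique, unknown or untested is made for them only; others in the source may bear on it.

In a functional assay on MCF7 cells (Homo sapiens) for antiproliferative activity, with a stated time of 5 days (a lower number here means a stronger inhibitor, a higher number a weaker inhibitor), compound 3 `CCCCc1ccc2[nH]c(-c3ccc(C(F)(F)F)cc3)c(/C=N/NC(=O)c3cccnc3)c2c1` gives 260 nM. Within the data shown here, that places it at the high end of the numbers so far, within the scatter of compound 1 `CCCCc1ccc2[nH]c(-c3ccc(CC)cc3)c(/C=N/NC(=O)c3ccncc3)c2c1` at 150 nM. Compound 2 `CCCCc1ccc2[nH]c(-c3ccc(OC)cc3)c(/C=N/NC(=O)c3cccnc3)c2c1` gives 75 nM, a clearly lower number.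

Moving to compound 4 `CCCCc1ccc2[nH]c(-c3ccc(CC)cc3)c(/C=N/NC(=O)c3cccnc3)c2c1` puts ethyl in place of trifluoromethyl on an aromatic carbon, para to a large group (ethyl in place of trifluoromethyl on an aromatic carbon). Among the measured compounds shown here, the one measured step at this place is modest: a 3.5-fold higher number from compound 2 to compound 3 (0.54 log units; beyond the scatter), with trifluoromethyl in place of methoxy. For the measured compounds named here, no measured pair compares ethyl with trifluoromethyl directly. Compound 1 carries the same 4-ethylphenyl but differs from compound 4 elsewhere, so compound 1 at 150 nM is only a rough guide.

Taken together, these numbers suggest a small move towards a lower number, and the expected size is a 2.0-fold lower number from compound 3 to compound 4 (0.30 log units; within the scatter), near the edge of the scatter. The estimate for compound 4 is 130 nM, with an expected range of 60 nM to 280 nM.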

Compound 4, half-maximal inhibitory concentration: 100 nM
Compound 4: middle estimate off by 1.3-fold (0.11 log units), on the high side; low and high end bracket the measured number.
By their numbers in this assay, from the lowest: compounds 2, 4, 1 and 3 (each within the scatter of the next, the first and the last beyond it).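

In this assay, ethyl and trifluoromethyl can now be compared directly at this place on the aromatic ring, and ethyl in place of trifluoromethyl gives a change beyond the scatter (a 2.6-fold lower number from compound 3 to compound 4 (0.41 log units; beyond the scatter)). Ethyl in place of methoxy stays within the scatter (a 1.3-fold higher number from compound 2 to compound 4 (0.12 log units; within the scatter)), so among the three compounds carrying pyridin-3-yl, trifluoromethyl alone stands apart from the other two groups, which cannot be told apart here. The result also gives the first single-change view of the other end of the molecule, where pyridin-3-yl in place of pyridin-4-yl stays within the scatter (a 1.5-fold lower number from compound 1 to compound 4 (0.18 log units; within the scatter)).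

From the compounds shown here alone, it remains open where an amine, a carboxylic acid or a longer chain at this place would fall relative to these three groups. Nothing available here explains why trifluoromethyl stands apart.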